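Benzothiazolyl for methoxyphenyl on the triazole-type ring nitrogen

This account rests on a few compounds, and the source may have more. Where it says the series, first, only, none or still open, it means among the compounds named here.

Working notes on the series. Compound 1 `COc1ccccc1-n1cc(COc2c(/C=C\C(=O)O)ccc(OC)c2CC=C(C)C)nn1` is the reference here. Going by the values given here, in a functional assay on HCT-116 cells (Homo sapiens) for cytotoxicity, read by MTT assay, with a stated time of 24 h (a higher number here means a weaker inhibitor, a lower number a stronger inhibitor), compound 1 gives 32200 nM, one of only two numbers in the set; compound 3 `COc1ccc(/C=C\C(=O)O)c(OCc2cn(-c3cccnc3Cl)nn2)c1CC=C(C)C` gives 23000 nM, and the step of a 1.4-fold lower number from compound 1 to compound 3 (0.15 log units; within the scatter) lies within the scatter. Compound 2 `COc1ccc(/C=C\C(=O)O)c(OCc2cn(-c3ccc(NC(C)=O)cc3)nn2)c1CC=C(C)C` has no result in this assay, reported as "not determined" (no result reported).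

Compound 4 `COc1ccc(/C=C\C(=O)O)c(OCc2cn(-c3nc4ccccc4s3)nn2)c1CC=C(C)C` is not yet measured. It differs from compound 1 in one place: 1,3-benzothiazol-2-yl in place of 2-methoxyphenyl on an aromatic nitrogen.

Among the compounds with values here, only one measured step touches this position, and it was a 1.4-fold lower number from compound 1 to compound 3 (0.15 log units; within the scatter), within the scatter. No step beyond the scatter is therefore expected in this assay; the estimated step is a 1.3-fold lower number from compound 1 to compound 4 (0.11 log units; within the scatter), in no reliable direction. Compound 4 is expected at 25000 nM, within a range of 8000 nM to 80000 nM.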

Compound 4, half-maximal inhibitory concentration: 16400 nM
For compound 4 the middle estimate is 1.5-fold (0.18 log units) above the measured one; measured number inside the range.
By their numbers in this assay, from the lowest: compounds 4, 3 and 1 (each within the scatter of the next).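

In this assay the aromatic nitrogen now carries three different groups, and both new steps stay within the scatter (a 2.0-fold lower number from compound 1 to compound 4 (0.29 log units; within the scatter); a 1.4-fold lower number from compound 3 to compound 4 (0.15 log units; within the scatter)). Thus 1,3-benzothiazol-2-yl, with its added five-membered aromatic ring, gives no readable change from either 2-methoxyphenyl or 2-chloropyridin-3-yl. No separate data on these compounds bear on this result.

All three groups with numbers are aromatic and carry no net charge. As far as these compounds go, whether a basic amine on the aromatic ring, a carboxylic acid there, or a plain alkyl chain in place of the ring would give a step beyond the scatter remains open.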